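A Methyl Added to a Weak Aminophenyl Analogue

The compounds below may be only part of what the source reports. "The series", "measured", "known", "first", "only" and "open" are said of these compounds alone.

Compound 1 `C=C(Br)C(=O)Nc1cccc(-c2cn3nc(-c4ccccc4)sc3n2)c1` was tested in a functional assay on CCRF-CEM cells (Homo sapiens) for inhibition, read by cell counting, with a stated time of 3 days (a higher number here means a weaker inhibitor, a lower number a stronger inhibitor), where compound 1 gives 960 nM. Compound 2 `C=C(Br)C(=O)Nc1cccc(-c2cn3nc(-c4ccc(C)cc4)sc3n2)c1` differs from it by methyl in place of hydrogen on an aromatic carbon, and in this assay compound 2 gives 1700 nM, a step of a 1.8-fold higher number from compound 1 to compound 2 (0.25 log units; within the scatter). Compound 3 `Nc1cccc(-c2cn3nc(-c4ccccc4)sc3n2)c1` differs from compound 1 by hydrogen in place of (1-bromoethenyl)carbonyl on a nitrogen on an aromatic ring; in this assay compound 3 gives 33000 nM, a step of a 34-fold higher number from compound 1 to compound 3 (1.54 log units; beyond the scatter). Compound 4 `Cc1ccc(-c2nn3cc(-c4cccc(N)c4)nc3s2)cc1` has not yet been measured. It differs from compound 3 by methyl in place of hydrogen on an aromatic carbon, the same change as between compound 1 and compound 2, now made on the core of compound 3. Because the earlier step measured a 1.8-fold higher number from compound 1 to compound 2 (0.25 log units; within the scatter), a change of similar size is expected for compound 4, namely a 1.5-fold higher number from compound 3 to compound 4 (0.18 log units; within the scatter). Compound 4 is therefore estimated to give 50000 nM, most likely between 22000 nM and 120000 nM.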

Compound 4, half-maximal inhibitory concentration: 5900 nM
The estimate for compound 4 lay 8.5-fold (0.93 log units) above the measured number, outside the stated range (below it).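

The methyl gave a 5.6-fold lower number from compound 3 to compound 4 (0.75 log units; beyond the scatter) in this assay, so its effect did not carry over unchanged from the core of compound 1: the same change on two cores in this assay, a 1.8-fold higher number (0.25 log units; within the scatter) from compound 1 to compound 2 and a 5.6-fold lower number (0.75 log units; beyond the scatter) from compound 3 to compound 4, 9.9-fold (1.00 log units) apart, beyond the scatter of two such steps

Removing the (1-bromoethenyl)carbonyl group likewise gave a smaller change with the methyl present, a 3.5-fold higher number from compound 2 to compound 4 (0.54 log units; beyond the scatter): the same change on two cores in this assay, a 34-fold higher number (1.54 log units; beyond the scatter) from compound 1 to compound 3 and a 3.5-fold higher number (0.54 log units; beyond the scatter) from compound 2 to compound 4, 9.9-fold (1.00 log units) apart, beyond the scatter of two such steps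

These four compounds show that the two changes do not simply add up in this series, but they do not show why, and one pair on each core gives no rule for other cores.

On these data alone, it remains open whether a chlorine or a methoxy group in place of that same hydrogen would follow the methyl on each core. As far as these compounds go, it is also open whether a plain acetyl group on the nitrogen would behave like the (1-bromoethenyl)carbonyl group.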